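Leaving 4-hydroxyphenyl for 3,5-dichlorophenyl on the shared core

The compounds below may be only part of what the source reports. "The series", "measured", "known", "first", "only" and "open" are said of these compounds alone.

Measured so far in a functional assay on HT-1080 cells (Homo sapiens) for cytotoxicity, read by MTT assay, with a stated time of 72 h; on this read-out higher numbers stand for weaker inhibition and lower numbers for stronger inhibition:
Compound 1 `COc1cccc(/C=C2\CCC/C(=C\c3ccccc3Br)C2=O)c1OC` gives 10800 nM
Compound 2 `COc1ccccc1/C=C1\CCC/C(=C\c2cccc(OC)c2OC)C1=O` gives 14100 nM
Compound 3 `COc1cccc(/C=C2\CCC/C(=C\c3ccc(O)cc3)C2=O)c1OC` gives > 20000 nM

The entry for compound 3 (> 20000 nM) is a limit of the assay and not a number. It is the only such entry here (the limit of > 20000 nM in this assay, at which 1 of the 3 values shown sits).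

Compound 4 `COc1cccc(/C=C2\CCC/C(=C\c3cc(Cl)cc(Cl)c3)C2=O)c1OC` keeps the shared core and changes one group, on a double-bonded chain carbon bound to a double-bonded ring carbon (3,5-dichlorophenyl in place of 4-hydroxyphenyl on a double-bonded chain carbon bound to a double-bonded ring carbon). Among the measured compounds shown here, no measured step makes this exact swap. The closest evidence comes from the same place, where 4-hydroxyphenyl arrives in two steps: one replaces 2-bromophenyl (an at least 1.8-fold higher number from compound 1 to compound 3 (0.26 log units; that floor lies within the scatter)) and the other replaces 2-methoxyphenyl (an at least 1.4-fold higher number from compound 2 to compound 3 (0.15 log units; that floor lies within the scatter)). Both are floors within the scatter, so they offer only a weak hint. The remaining step, methoxy in place of bromo (a 1.3-fold higher number from compound 1 to compound 2 (0.12 log units; within the scatter)), also stays within the scatter.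

Once 4-hydroxyphenyl leaves, a modest move to a lower number in this assay is therefore expected, landing near compound 1 (10800 nM) and compound 2 (14100 nM). The estimate means this expected step (an at least 2.0-fold lower number from compound 3 to compound 4 (0.30 log units; that floor lies within the scatter)). For compound 4 the estimated value is 10000 nM with an expected range from 4000 nM to 20000 nM in this measurement.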

Compound 4, half-maximal inhibitory concentration: 6100 nM
Compound 4: middle estimate off by 1.6-fold (0.21 log units), on the high side; measured number inside the range.
By their numbers in this assay, from the lowest: compounds 4, 1 and 2 (each within the scatter of the next, the first and the last beyond it). At a limit, above all of these: compound 3.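

Placing 3,5-dichlorophenyl on the double-bonded chain carbon bound to a double-bonded ring carbon gives, in this assay, steps at this place that clear the scatter, which none of the earlier steps did: an at least 3.2-fold lower number from compound 3 to compound 4 (0.51 log units; beyond the scatter) when it replaces 4-hydroxyphenyl, and a 2.3-fold lower number from compound 2 to compound 4 (0.36 log units; beyond the scatter) when it replaces 2-methoxyphenyl. Against 2-bromophenyl the same change gives a 1.8-fold lower number from compound 1 to compound 4 (0.25 log units; within the scatter), so compound 1 and compound 4 cannot be told apart here, and 3,5-dichlorophenyl is separated only from 2-methoxyphenyl and 4-hydroxyphenyl. The entry for compound 3 is a limit and not a number, so the step from it gives only a floor and its true size stays unknown: the limit of > 20000 nM in this assay, at which 1 of the 4 values shown sits.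

Still open, going by these compounds, is whether 3,5-dichlorophenyl would differ from a plain phenyl or from a phenyl carrying a single chlorine, which would show whether both chlorines count. Also open, on these data alone, is how a ring carrying an amine or a carboxylic acid would behave at this place, and whether the pattern seen here would hold on a core with a different group on its other side.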